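Replacing the Triazolylsulfanyl Arm with Methylpiperazine

A few compounds are considered here, and "the series" means these few. Any claim that something is new, unique, unknown or untested is made for them only; others in the source may bear on it.

Compound 1, `Cn1c(-c2ccc(NC(=O)CSc3nc4cc(Cl)ccc4o3)cc2)nc(-c2ccccc2)c1-c1ccccc1`, gives 42.5% in a functional assay on HT-29 cells (Homo sapiens) for cytotoxicity, read by MTT assay, with a stated time of 24 h, tested at 16 ug/mL; a higher number here means a stronger effect of the compound at the concentration tested, a lower number a weaker effect.
Compound 2, `Cn1c(-c2ccc(NC(=O)CSc3nc4ccccc4s3)cc2)nc(-c2ccccc2)c1-c1ccccc1`, gives 47.2%.
Compound 3, `Cn1cnnc1SCC(=O)Nc1ccc(-c2nc(-c3ccccc3)c(-c3ccccc3)n2C)cc1`, gives 59.1%.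

Compound 3 stands highest of the three: the step of a number 16.6 percentage points higher from compound 1 to compound 3 (beyond the scatter) and the step of a number 11.9 percentage points higher from compound 2 to compound 3 (beyond the scatter) both lie beyond the scatter, whereas the step of a number 4.7 percentage points higher from compound 1 to compound 2 (within the scatter) does not. Compound 4, `CN1CCN(CC(=O)Nc2ccc(-c3nc(-c4ccccc4)c(-c4ccccc4)n3C)cc2)CC1`, differs from compound 3 by 4-methylpiperazin-1-yl in place of (4-methyl-4H-1,2,4-triazol-3-yl)sulfanyl on a saturated chain carbon bound to a carbonyl carbon. Within the data shown here, every measured step exchanges one aromatic ring on the sulfur for another; none removes the sulfur or brings in a non-aromatic ring, so no measured step bears directly on this change. Compound 4 is therefore expected to give 45%, between 25% and 65%. That estimate means a step of a number 14.1 percentage points lower from compound 3 to compound 4 (beyond the scatter), expected to be modest or within the scatter.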

Compound 4, a percentage reported as activity, at one concentration (the size of the read-out at that concentration, not a potency): 33.7%
Estimate against measurement, compound 4: 11.3 percentage points above, within the range that was stated.
By their numbers in this assay, from the lowest: compounds 4, 1 and 2 (each within the scatter of the next, the first and the last beyond it); then compound 3.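

The earlier compounds shown here only exchanged one aromatic ring on the sulfur for another, whereas this change replaces the whole arm on a saturated chain carbon bound to a carbonyl carbon. In this assay, 4-methylpiperazin-1-yl gives a number 25.4 percentage points lower from compound 3 to compound 4 (beyond the scatter) and a number 13.5 percentage points lower from compound 2 to compound 4 (beyond the scatter), yet a number 8.8 percentage points lower from compound 1 to compound 4 (within the scatter), so the piperazine arm falls clearly short of two sulfur arms but not of the third. Nothing measured here explains this difference.

On these data alone, the sulfur and the aromatic ring leave in one step, so their separate contributions remain unknown. A 4-methyl-4H-1,2,4-triazol-3-yl group joined through an amine nitrogen, or a morpholine ring, could begin to separate them.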